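Removing one methyl from the amine of compound 1

The source may report more compounds than this note shows. Statements on the series, on what has been measured and on what is new or still open speak of the compounds shown alone.

Measured compounds:
- compound 1 `COc1ccc(Cc2nc(-c3cc(Br)c(OCCCN(C)C)c(Br)c3)c[nH]c2=O)cc1Br`: 7900 nM
- compound 2 `COc1ccc(Cc2nc(-c3cc(Br)c(OCCCN(C)C)c(Br)c3)cnc2Cl)cc1Br`: "not determined" (no result reported)

Going by the values given here, compound 1 `COc1ccc(Cc2nc(-c3cc(Br)c(OCCCN(C)C)c(Br)c3)c[nH]c2=O)cc1Br` is the only compound of this pair with a number. In a functional assay on COLO 205 cells (Homo sapiens) for inhibition, read by MTT assay, with a stated time of 24 h (on this read-out higher numbers stand for weaker inhibition and lower numbers for stronger inhibition), compound 1 gives 7900 nM, which places it as the sole reference point. In this assay compound 2 `COc1ccc(Cc2nc(-c3cc(Br)c(OCCCN(C)C)c(Br)c3)cnc2Cl)cc1Br` gives "not determined" (no result reported), so nothing can be said of how the two compare. Among the compounds with values here, no step between two measured compounds is available in this set.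

Compound 3 `CNCCCOc1c(Br)cc(-c2c[nH]c(=O)c(Cc3ccc(OC)c(Br)c3)n2)cc1Br` differs from compound 1 in one place: hydrogen in place of methyl on an amine nitrogen. The dimethylamino group of compound 1 becomes a methylamino group, the rest of the molecule being unchanged. With only the value of compound 1 to go on, the step from compound 1 to compound 3 in this assay is expected to be small, and the author expects no change beyond the usual scatter, with the step of a 1.0-fold higher number from compound 1 to compound 3 (0.01 log units; within the scatter) estimated accordingly.

For compound 3 the estimate in this assay is therefore 8000 nM, expected to fall between 3000 nM and 25000 nM.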

Compound 3, half-maximal inhibitory concentration: 10300 nM
Beside the measured number, compound 3's estimate is 1.3-fold (0.11 log units) below it, and the stated range covers the measured number.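

In this assay the removal of one methyl from the amine nitrogen gives a 1.3-fold higher number from compound 1 to compound 3 (0.12 log units; within the scatter) and stays within the scatter, so the dimethylamino and methylamino ends of the chain cannot be told apart on this read-out. Going by these compounds alone, this is the first step between two measured compounds in the set, and it shows that this amine nitrogen, whose other neighbours are saturated chain carbons, can carry either a methyl or a hydrogen with no difference beyond what repeated measurements would produce. Nothing measured here offers a reason why the two compounds read alike.

Going by these compounds, what remains open is whether this tolerance extends further along the same line, to a primary amine with both methyls gone, to a larger substituent on the nitrogen such as ethyl, or to a ring amine such as pyrrolidine or morpholine at the end of the chain. On these data alone, it is equally open whether a longer or shorter chain, or a carboxylic acid in place of the amine, would read the same on the shared core.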